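Trifluoromethoxy for Dimethylamino on a Weakly Cytotoxic Compound

The source may report more compounds than this note shows. Statements on the series, on what has been measured and on what is new or still open speak of the compounds shown alone.

Among the measured compounds shown here, in a functional assay on T47D cells (Homo sapiens) for cytotoxicity, read by MTT assay, with a stated time of 2 days (on this read-out lower numbers stand for stronger inhibition and higher numbers for weaker inhibition), compound 1 (`Cc1ccc2nc(-c3ccccc3N(C)C)[nH]c(=O)c2c1`) gives 26700 nM, the only actual number available so far. Compound 2 (`Cc1ccc2c(=O)[nH]c(-c3cccc(C(F)(F)F)c3)nc2c1`) reaches only a limit of the assay, > 50000 nM. Compound 3 (`Cc1ccc2nc(-c3ccccc3OC(F)(F)F)[nH]c(=O)c2c1`) has trifluoromethoxy in place of dimethylamino on an aromatic carbon, (trifluoromethoxy in place of dimethylamino on an aromatic carbon). For the measured compounds named here, no measured step bears directly on this change. In this assay, a small weakening, barely beyond the usual scatter, is expected, and the estimated step is a 1.3-fold higher number from compound 1 to compound 3 (0.13 log units; within the scatter). The expected value for compound 3 is 36000 nM, with an estimated range of 15000 nM to 50000 nM.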

Compound 3, half-maximal inhibitory concentration: > 50000 nM
Compound 3 was reported as a limit (the forecaster's own chance of this, stated with the estimate: 40%); middle value at least 1.3-fold (0.14 log units) away from the limit.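

In this assay, putting trifluoromethoxy in place of dimethylamino on this aromatic carbon, ortho to a large group, gives an at least 1.8-fold higher number from compound 1 to compound 3 (0.27 log units; that floor lies within the scatter). Among the compounds shown here, this is the first step that can be read at this position, but it is only a floor, and compound 3 is reported as a limit rather than a number. The true size of the step therefore stays unknown, and compound 1 remains the only compound with an actual value: the limit of > 50000 nM in this assay, at which 2 of the 3 values shown sit.

As far as these compounds go, it remains open whether a methoxy group or a primary amine at this position would give a measurable value. From the compounds shown here alone, it is also open whether dimethylamino matters specifically there.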